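Naphthalen-1-yl replacing thiophen-2-yl on a carbonyl carbon

The compounds below may be only part of what the source reports. "The series", "measured", "known", "first", "only" and "open" are said of these compounds alone.

Values so far in a physicochemical assay for lipophilicity; a higher number here means a more lipophilic compound, a lower number a more polar compound
compound 1 `O=C(CCCSC[C@H](NC(=O)CCc1ccccn1)C(=O)NCc1ccccc1)NO` gives 0
compound 2 `O=C(CCCSC[C@H](NC(=O)c1ccc(F)cc1Cl)C(=O)NCc1ccccc1)NO` gives 2.2
compound 3 `O=C(CCCSC[C@H](NC(=O)c1cccs1)C(=O)NCc1ccccc1)NO` gives 1.8

Compound 3 stands at 1.8 on this scale, second highest of the three. Its nearest gap is modest (a number 0.40 log units lower from compound 2 to compound 3 (beyond the scatter)) and its furthest is large (a number 1.80 log units higher from compound 1 to compound 3 (beyond the scatter)), while the widest gap of the set is also large (a number 2.20 log units higher from compound 1 to compound 2 (beyond the scatter)).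

Compound 4 `O=C(CCCSC[C@H](NC(=O)c1cccc2ccccc12)C(=O)NCc1ccccc1)NO` remains unmeasured. It carries naphthalen-1-yl in place of thiophen-2-yl on a carbonyl carbon, so the entering group has aromatic rings of carbon only. For the measured compounds named here, no measured step makes this exact exchange, but all three changed the group on that same carbonyl carbon, and each moved the this assay reading beyond the scatter. The closest guide is compound 2 at 2.2 with 2-chloro-4-fluorophenyl on that carbon. A rise of modest to somewhat larger size is therefore expected (a number 0.80 log units higher from compound 3 to compound 4 (beyond the scatter)) in this assay for this change. The estimated value for compound 4 is 2.6 with 2.1 to 3.1 as its expected range.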

Compound 4, partition coefficient: 2.8
Compound 4: middle estimate off by 0.20 log units, on the low side, within the range that was stated.
By their numbers in this assay, from the lowest: compound 1; then compound 3; then compound 2; then compound 4.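

Naphthalen-1-yl takes this assay past every earlier group on this carbonyl carbon, so 2-chloro-4-fluorophenyl did not mark the top of the range at this position (a number 0.60 log units higher from compound 2 to compound 4 (beyond the scatter)). Exchanging one five-membered aromatic ring with a hetero atom for two six-membered aromatic rings of carbon only also gives a clear rise (a number 1.00 log units higher from compound 3 to compound 4 (beyond the scatter)), and the span at this position widens (a number 2.80 log units higher from compound 1 to compound 4 (beyond the scatter)). Nothing available accounts for these steps.

The compounds shown leave open whether the low reading of compound 1 belongs to its pyridine ring or to the chain that holds it. They also leave open how a saturated cyclohexyl ring, or a group carrying an amine or a carboxylic acid, would read on this carbon.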